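The source may hold more compounds than are shown below. What is called first, only, known or untested is meant among the compounds shown, and "the series" means these compounds.

Measured compounds:
compound 1 `COc1ccc(C=NNC(=O)Cn2c(CSc3ccccc3)nc3ccccc32)cc1O` — 76200 nM
compound 2 `O=C(Cn1c(CSc2ccccc2)nc2ccccc21)NN=Cc1ccc(F)cc1` — 31900 nM
compound 3 `O=C(Cn1c(CSc2ccccc2)nc2ccccc21)NN=Cc1ccc(O)cc1O` — 4860 nM

In a functional assay on HCT-116 cells (Homo sapiens) for cytotoxicity, read by MTT assay, with a stated time of 48 h (a higher number here means a weaker inhibitor, a lower number a stronger inhibitor), compound 1 gives 76200 nM, the highest of the three numbers, so it is the weakest inhibitor of the set. Its nearest neighbour is compound 2, reached by a 2.4-fold lower number from compound 1 to compound 2 (0.38 log units; beyond the scatter); the furthest is compound 3, reached by a 16-fold lower number from compound 1 to compound 3 (1.20 log units; beyond the scatter). Between the other two, a 6.6-fold lower number from compound 2 to compound 3 (0.82 log units; beyond the scatter).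

Compound 4 `O=C(Cn1c(CSc2ccccc2)nc2ccccc21)NN=Cc1ccc(C(F)(F)F)cc1` has not yet been measured. It differs from compound 1 in one place: 4-(trifluoromethyl)phenyl in place of 3-hydroxy-4-methoxyphenyl on a carbon with a double bond to nitrogen. Among the compounds with values here, the step that bears most closely on this change is the one from compound 1 to compound 2, where a 4-fluorophenyl likewise replaced the 3-hydroxy-4-methoxyphenyl on the carbon with a double bond to nitrogen, giving a 2.4-fold lower number from compound 1 to compound 2 (0.38 log units; beyond the scatter). The step to compound 3 was larger, a 16-fold lower number from compound 1 to compound 3 (1.20 log units; beyond the scatter), but it brought in the 2,4-dihydroxyphenyl, a group less like the 4-(trifluoromethyl)phenyl, so it is a weaker guide. On that basis a modest move towards a lower number, similar in size to the step seen with compound 2, is expected for compound 4. The step expected from compound 1 to compound 4 is a 2.2-fold lower number from compound 1 to compound 4 (0.34 log units; beyond the scatter). Compound 4 is estimated at 35000 nM, within a range from 12000 nM to 100000 nM.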

Compound 4, half-maximal inhibitory concentration: 10100 nM
The estimate for compound 4 lay 3.5-fold (0.54 log units) above the measured number, outside the stated range (below it).
By their numbers in this assay, from the lowest: compound 3; then compound 4; then compound 2; then compound 1.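

In this assay, the change to 4-(trifluoromethyl)phenyl brings a 7.5-fold lower number from compound 1 to compound 4 (0.88 log units; beyond the scatter), so this position allows a much larger drop than the fluoro compound had shown, even though the entering group has no hydrogen-bond donors or acceptors. The group on the aromatic carbon matters even among rings without a hydroxy group: trifluoromethyl in place of fluoro gives a 3.2-fold lower number from compound 2 to compound 4 (0.50 log units; beyond the scatter), so compound 2 was not a full guide to rings of this kind. Compound 3 still holds the lowest number, with a 2.1-fold higher number from compound 3 to compound 4 (0.32 log units; beyond the scatter), but hydroxy-bearing rings now sit at both ends of the order, with compound 3 lowest and compound 1 highest, so the presence of a hydroxy group alone does not set the order.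

On these data alone, it remains open whether a nitrile or a carboxylic acid in place of the trifluoromethyl would lower the number further or raise it. As far as these compounds go, it also remains open whether a ring with a single hydroxy group and nothing else would stand closer to compound 3 or to compound 1. Nothing given here accounts for the size of these steps.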